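The source may report more compounds than this note shows. Statements on the series, on what has been measured and on what is new or still open speak of the compounds shown alone.

Measured so far:
compound 1, `Cc1cc(O)c(C2=NN(c3ccc(S(N)(=O)=O)cc3)C(c3ccc(Cl)cc3)C2)cc1Cl`, 65.8% in a functional assay on the whole organism (strain Wistar) for inhibition, with Rattus norvegicus as the target, read by paw edema, with stated times of 30 min and 3 h, at a dose of 20 mg/kg by the oral route; a higher number here means more inhibition at the dose given (going by the name of the read-out), a lower number less inhibition
compound 2, `Cc1cc(O)c(C2=NN(c3ccc(S(N)(=O)=O)cc3)C(/C=C/c3ccccc3)C2)cc1Cl`, 78.9% in this assay

Compound 2 stands highest of these two numbers; its nearest neighbour is compound 1, and the step of a number 13.1 percentage points higher from compound 1 to compound 2 (beyond the scatter) lies beyond the scatter. That step, 2-phenylethenyl in place of 4-chlorophenyl on a saturated ring carbon, is the only one measured, and it shows that what sits on this carbon matters.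

Compound 3, `COc1ccc(C2CC(c3cc(Cl)c(C)cc3O)=NN2c2ccc(S(N)(=O)=O)cc2)c(OC)c1OC`, has not yet been measured. It differs from compound 2 by 2,3,4-trimethoxyphenyl in place of 2-phenylethenyl on a saturated ring carbon. Going by the values given here, no measured step moves between two aryl groups at this carbon, so the size of the change can only be guessed. Since compound 1, the other aryl-bearing member, gives 65.8%, compound 3 is expected to land between the two measured values, with the step of a number 10.9 percentage points lower from compound 2 to compound 3 (beyond the scatter) estimated downward. The estimate for compound 3 is 68%, with a range from 52% to 82%.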

Compound 3, a percentage reported as inhibition, in the whole organism at one dose (the size of the read-out at that dose, not a potency): 68.4%
The estimate for compound 3 lay 0.4 percentage points below the measured number, within the range that was stated.
By their numbers in this assay, from the lowest: compounds 1 and 3 (each within the scatter of the next); then compound 2.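

Placing 2,3,4-trimethoxyphenyl on this saturated ring carbon gives a number 10.5 percentage points lower from compound 2 to compound 3 (beyond the scatter) in this assay, so this aryl group does not match the 2-phenylethenyl group. The two aryl groups cannot be told apart, with a number 2.6 percentage points higher from compound 1 to compound 3 (within the scatter), even though 2,3,4-trimethoxyphenyl carries three hydrogen-bond acceptors, so among these three compounds, compound 2 alone stands out. Nothing available explains this difference.

The compounds shown leave open whether the double bond of the 2-phenylethenyl group matters, which a 2-phenylethyl group, the same chain without that bond, could test. They also leave open how a small methyl group, or an aryl ring bearing a dimethylamino group, would compare at this carbon.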